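The compounds below may be only part of what the source reports. "The series", "measured", "known", "first", "only" and "open" are said of these compounds alone.

Measured in a functional assay on HT-29 cells (Homo sapiens) for inhibition, read by sulforhodamine B assay, with a stated time of 48 h; a higher number here means a weaker inhibitor of growth, a lower number a stronger inhibitor of growth:

compound 1, `COc1ccc(NC(=O)Nc2n[nH]c3ccccc23)cc1`, > 100000 nM
compound 2, `CCCCOc1ccc(NC(=O)n2nc(N)c3ccccc32)cc1`, 13500 nM
compound 3, `Nc1nn(C(=O)Nc2c(F)cccc2F)c2ccccc12`, 74600 nM

The value of compound 1 is a limit of this assay, not a number, as noted in the limit of > 100000 nM in this assay, at which 1 of the 3 values shown sits. Among the two numbers, compound 2 stands lowest; compound 3 sits beyond the scatter above it, and compound 1 sets no number at all. Compound 4, `Nc1nn(C(=O)Nc2ccc(Cc3ccccc3)cc2)c2ccccc12`, has not yet been measured in this assay. Its structure departs from compound 2 in one place: benzyl in place of butoxy on an aromatic carbon. Both groups lack any hydrogen-bond donor, and the group that enters is larger by two heavy atoms and brings an aromatic ring while the oxygen of the butoxy leaves. Within the data shown here, with no measured pair separating these two groups, the step from compound 2 to compound 4 is expected to be small, at most modest in either direction, and the estimate is a 1.1-fold lower number from compound 2 to compound 4 (0.05 log units; within the scatter). Compound 4 is therefore estimated to give 12000 nM in this assay, within a range of 3000 nM to 45000 nM.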

Compound 4, concentration for 50% growth inhibition: 2390 nM
For compound 4 the middle estimate is 5.0-fold (0.70 log units) above the measured one, and the stated range ends above it.
By their numbers in this assay, from the lowest: compound 4; then compound 2; then compound 3. At a limit, above all of these: compound 1.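

In this assay, benzyl in place of butoxy on an aromatic carbon, para to a large group, gives a 5.6-fold lower number from compound 2 to compound 4 (0.75 log units; beyond the scatter), so the number at this position depends on which of these two groups it carries. Benzyl brings a six-membered aromatic ring of carbon only and butoxy takes its oxygen away, and this single step cannot separate the ring from the loss of oxygen. Nothing measured among these compounds gives a reason for the step.

From the compounds shown here alone, it remains open whether phenoxy, which keeps both an oxygen and an aromatic ring, would give a number closer to that of compound 4 or that of compound 2. A plain pentyl chain at the same place would test whether the aromatic ring is needed at all.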